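Swapping nitro for amino on two different cores

The source may report more compounds than this note shows. Statements on the series, on what has been measured and on what is new or still open speak of the compounds shown alone.

In a functional assay on MDA-MB-468 cells (Homo sapiens) for antiproliferative activity, read by MTT assay, with a stated time of 72 h (on this read-out lower numbers stand for stronger inhibition and higher numbers for weaker inhibition), compound 1 `COc1ccc(-n2ccnc2-c2cc(OC)c(OC)c(OC)c2)cc1[N+](=O)[O-]` gives 100 nM. Compound 2 `COc1ccc(-n2ccnc2-c2cc(OC)c(OC)c(OC)c2)cc1N` carries one change, (amino in place of nitro on an aromatic carbon); in this assay compound 2 gives 90 nM, so the step is a 1.1-fold lower number from compound 1 to compound 2 (0.05 log units; within the scatter). Compound 3 `COc1ccc(C(=O)Oc2cc(OC)c(OC)c(OC)c2)cc1[N+](=O)[O-]` is built on a different core, and the difference between the two cores is not broken down here. In this assay compound 3 gives 35200 nM, a much higher number than compound 1 or compound 2. Compound 4 `COc1ccc(C(=O)Oc2cc(OC)c(OC)c(OC)c2)cc1N` differs from compound 3 by amino in place of nitro on an aromatic carbon, the same change as that from compound 1 to compound 2, at a place described in the same words. Since the measured step of a 1.1-fold lower number from compound 1 to compound 2 (0.05 log units; within the scatter) stayed within the scatter, the expected step is a 1.1-fold lower number from compound 3 to compound 4 (0.04 log units; within the scatter). Compound 4 is therefore estimated at 32000 nM, likely between 10000 nM and 100000 nM.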

Compound 4, half-maximal inhibitory concentration: > 100000 nM
Compound 4: a limit, no number; the forecaster's own chance of this, stated with the estimate: 15%; middle value at least 3.1-fold (0.49 log units) away from the limit.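

In this assay compound 4 gives > 100000 nM, which is a limit of the assay and not a number. On the core of compound 3, amino in place of nitro gives an at least 2.8-fold higher number from compound 3 to compound 4 (0.45 log units; beyond the scatter), so the step seen on the core of compound 1 does not carry over to this second core: the same change on two cores in this assay, a 1.1-fold lower number (0.05 log units; within the scatter) from compound 1 to compound 2 and an at least 2.8-fold higher number (0.45 log units; beyond the scatter) from compound 3 to compound 4, at least 3.1-fold (0.49 log units) apart, beyond the scatter of two such steps

This comparison rests on one pair of compounds per core, and the limit hides the full size of the second step, so it does not show why the two cores differ or how large the gap really is. The compounds shown leave open how a hydroxyl group or an acetamide at the same place would behave on each core.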